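Removing the methyl from a methoxy group

This account rests on a few compounds, and the source may have more. Where it says the series, first, only, none or still open, it means among the compounds named here.

Measured compounds in this assay:
compound 1 `O=C(Nc1cccc(-n2cc(-c3ccncc3)c(-c3ccc(Cl)c(O)c3)n2)c1)Nc1cccc(C(F)(F)F)c1`: > 32500 nM
compound 2 `COc1cc(-c2nn(-c3cccc(NC(=O)Nc4cc(C(F)(F)F)cc(C(F)(F)F)c4)c3)cc2-c2ccncc2)ccc1Cl`: 15400 nM
compound 3 `COc1cc(-c2nn(-c3cccc(NC(=O)Nc4cccc(C(F)(F)F)c4)c3)cc2-c2ccncc2)ccc1Cl`: > 50000 nM

Of the compounds shown here, three have been tested in a functional assay on SK-OV-3 cells (Homo sapiens) for inhibition, read by sulforhodamine B assay, with a stated time of 48 h; on this read-out lower numbers stand for higher toxicity in this test and higher numbers for lower toxicity in this test. For compound 1 the value is a limit of the assay and not a number. For compound 3 the value is likewise only a limit. Compound 2 is the only one of the three that gives a number, so its standing against the other two can be read only as far as the limits allow.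

Two measured steps exist. One, a step that the two limits leave unreadable from compound 1 to compound 3, is methyl in place of hydrogen on an oxygen on an aromatic ring. The other, an at least 3.2-fold higher number from compound 2 to compound 3 (0.51 log units; beyond the scatter), is hydrogen in place of trifluoromethyl on an aromatic carbon and is at least modest.

Compound 4 `O=C(Nc1cccc(-n2cc(-c3ccncc3)c(-c3ccc(Cl)c(O)c3)n2)c1)Nc1cc(C(F)(F)F)cc(C(F)(F)F)c1` has not been measured. It differs from compound 2 by hydrogen in place of methyl on an oxygen on an aromatic ring, that is methoxy to hydroxy. Among the measured compounds shown here, the only measured step that bears on this change is the one running the same way in reverse, and that step is unreadable because of the limit of > 32500 nM in this assay, at which 1 of the 3 values shown sits, and (the limit of > 50000 nM in this assay, at which 1 of the 3 values shown sits). The step involving the trifluoromethyl group concerns a different place and gives no guidance here. No direction can therefore be expected beyond the scatter.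

Compound 4 is expected to give about 17000 nM in this assay. For compound 4 the expected range runs from 5000 nM to 50000 nM. The step that this estimate means, a 1.1-fold higher number from compound 2 to compound 4 (0.04 log units; within the scatter), is expected to stay within the scatter.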

Compound 4, concentration lethal to 50% of the cells: > 50000 nM
Compound 4: only a limit was reported (the forecaster's own chance of this, stated with the estimate: 35%); middle value at least 2.9-fold (0.46 log units) from the limit.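

Among the compounds shown here, with an at least 3.2-fold higher number from compound 2 to compound 4 (0.51 log units; beyond the scatter), the change from methoxy to hydroxy on the 4-chloro-3-methoxyphenyl group can be read for the first time in this assay, and it runs in the same direction as an at least 3.2-fold higher number from compound 2 to compound 3 (0.51 log units; beyond the scatter). For compound 4 the result, > 50000 nM, is a limit of the assay and not a number. Compound 2 therefore remains the only one of the four compounds with a number, and each of the two single changes shown from it, one on the oxygen and one on the aromatic carbon, ends at a limit.

Going by these compounds, the steps from compound 1 to compound 3 and from compound 1 to compound 4 cannot be read, so the effect of the methyl on the oxygen alongside a single trifluoromethyl group, and of the second trifluoromethyl group alongside the hydroxy, stays open: the limit of > 32500 nM in this assay, at which 1 of the 4 values shown sits. Also open is whether a longer chain such as ethoxy on this oxygen, or an amine in place of the hydroxy, would give a number in this assay rather than a limit.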